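The compounds below may be only part of what the source reports. "The series", "measured", "known", "first", "only" and "open" are said of these compounds alone.

In a functional assay on A-375 cells (Homo sapiens) for inhibition, read by CCK-8 assay, with a stated time of 72 h (a higher number here means a weaker inhibitor, a lower number a stronger inhibitor), compound 1 (`Nc1ccccc1NC(=O)c1ccc(CNC(=O)c2n[nH]cc2NC(=O)c2c(F)cccc2Cl)cc1`) gives 1200 nM while compound 2 (`Nc1ccccc1NC(=O)c1ccc(CNC(=O)c2n[nH]cc2NC(=O)c2ccccc2)cc1`) gives 1590 nM and compound 3 (`Nc1ccccc1NC(=O)c1ccc(CNC(=O)c2n[nH]cc2NC(=O)c2ccccc2F)cc1`) gives 2270 nM as its reading. Compound 3 thus lies within the scatter of both compound 1 and compound 2. Compound 4 (`COc1ccccc1C(=O)Nc1c[nH]nc1C(=O)NCc1ccc(C(=O)Nc2ccccc2N)cc1`) carries methoxy in place of fluoro on an aromatic carbon, ortho to a large group (methoxy in place of fluoro on an aromatic carbon). Among the measured compounds shown here, no measured step makes this exact exchange, but three change the same ring. With a 1.4-fold higher number from compound 2 to compound 3 (0.15 log units; within the scatter) and a 1.3-fold higher number from compound 1 to compound 2 (0.12 log units; within the scatter) and also a 1.9-fold higher number from compound 1 to compound 3 (0.28 log units; within the scatter) on that ring, no step beyond the scatter is expected in this assay in either direction. The expected step is a 1.3-fold lower number from compound 3 to compound 4 (0.10 log units; within the scatter) as estimated here. For compound 4 the estimated value is 1800 nM (expected range 800 nM to 4000 nM).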

Compound 4, half-maximal inhibitory concentration: 2660 nM
For compound 4 the middle estimate is 1.5-fold (0.17 log units) below the measured one, within the range that was stated.
By their numbers in this assay, from the lowest: compounds 1, 2, 3 and 4 (each within the scatter of the next, the first and the last beyond it).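

In this assay a methoxy ortho to a large group brings no step beyond the scatter, with a 1.2-fold higher number from compound 3 to compound 4 (0.07 log units; within the scatter) and a 1.7-fold higher number from compound 2 to compound 4 (0.22 log units; within the scatter) as its two readings. Among the compounds shown here, only a 2.2-fold higher number from compound 1 to compound 4 (0.35 log units; beyond the scatter) passes the scatter, modestly, and it is the first step on this ring to do so, starting from the 2-chloro-6-fluorophenyl group. Nothing measured alongside these numbers bears on this result. Still open, on these data alone, is whether an amine or a carboxylic acid on this ring would move the number beyond the scatter from the unsubstituted phenyl.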